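Solubility series: replacement at the chain carbon, compound 4

The compounds below may be only part of what the source reports. "The series", "measured", "known", "first", "only" and "open" are said of these compounds alone.

Compound 1 `CC(C)NC(=O)CC(c1ccc(-c2ccc3cccc(F)c3c2)[nH]c1=O)C(C)C` is measured in a physicochemical assay for solubility, in phosphate buffer, measured as kinetic solubility (on this read-out higher numbers stand for higher solubility and lower numbers for lower solubility), at 18000 nM. Among the three compounds with numbers, compound 1 stands second highest, with compound 2 `CC(C)C(Nc1nccs1)c1ccc(-c2ccc3cccc(F)c3c2)[nH]c1=O` nearest at 16100 nM and compound 3 `CC(C)C(c1ccc(-c2ccc3cccc(F)c3c2)[nH]c1=O)N1CCNC1=O` furthest at 24900 nM. The change to compound 4 `CC(C)C(Cc1noc(=O)[nH]1)c1ccc(-c2ccc3cccc(F)c3c2)[nH]c1=O` is a group of 6 heavy atoms (2 carbon, 2 nitrogen, 2 oxygen; one five-membered aromatic ring with 3 hetero atoms) in place of a group of 6 heavy atoms (4 carbon, 1 nitrogen, 1 oxygen; no ring), on a saturated chain carbon, two bonds along the chain from an aromatic carbon. Among the measured compounds shown here, two measured steps touch the same position of the shared core: a 1.1-fold lower number from compound 1 to compound 2 (0.05 log units; within the scatter) and a 1.4-fold higher number from compound 1 to compound 3 (0.14 log units; within the scatter), and the remaining pair gives a 1.5-fold higher number from compound 2 to compound 3 (0.19 log units; within the scatter). All three steps swap one group of comparable size at this chain carbon, and none of them moves the solubility beyond the scatter, so the replacement in compound 4 is expected to behave the same way, with no step beyond the scatter in either direction. Compound 4 is therefore estimated at 20000 nM in this assay, with a range from 9000 nM to 45000 nM. For the measured compounds named here, the expected step of a 1.1-fold higher number from compound 1 to compound 4 (0.05 log units; within the scatter) rests on the three compounds measured so far.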

Compound 4, solubility: 30400 nM
The estimate for compound 4 lay 1.5-fold (0.18 log units) below the measured number, within the range that was stated.
By their numbers in this assay, from the lowest: compounds 2, 1, 3 and 4 (each within the scatter of the next).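

In this assay this chain carbon also carries a group with a five-membered aromatic ring with 3 hetero atoms without a step beyond the scatter (a 1.7-fold higher number from compound 1 to compound 4 (0.23 log units; within the scatter)), and the same holds against the two other ring-bearing groups (a 1.2-fold higher number from compound 3 to compound 4 (0.09 log units; within the scatter); a 1.9-fold higher number from compound 2 to compound 4 (0.28 log units; within the scatter)). Across compounds 1 to 4, the open-chain isopropylcarbamoyl group and three different five-membered rings therefore all remain within the scatter of one another, and no compound shown goes against this. Nothing available here explains why the numbers stay so close. 

Still open, from the compounds shown here alone, is whether an amine or a carboxylic acid at this chain carbon would give a step beyond the scatter. Equally unresolved is whether a longer chain between this carbon and the new ring would leave the number within the scatter.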